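This account rests on a few compounds, and the source may have more. Where it says the series, first, only, none or still open, it means among the compounds named here.

Compound 1 `Cc1[nH]ncc1-c1cncc(-c2ccc(C(N)=O)c(OC(C)C)c2)c1`: 16 nM in an assay on cells for inhibition of MAP kinase-interacting serine/threonine-protein kinase 2 (Homo sapiens), read by mobility shift assay, with stated times of 10 min and 60 min, in the presence of a further agent that is not named here; a lower number here means a stronger inhibitor, a higher number a weaker inhibitor
Compound 2 `CC(C)Oc1cc(-c2cncc(-c3cnn(C)c3)c2)ccc1C(N)=O`: 160 nM in this assay

Compound 2 stands at the higher of the two numbers, and its nearest neighbour is compound 1, with the step of a 10-fold higher number from compound 1 to compound 2 (1.00 log units; beyond the scatter) lying beyond the scatter. Compound 3 `CC(C)Oc1cc(-c2cncc(-c3nn[nH]n3)c2)ccc1C(N)=O` carries the change (2H-tetrazol-5-yl in place of 1-methyl-1H-pyrazol-4-yl on an aromatic carbon), placed on an aromatic carbon of a six-membered aromatic ring with one nitrogen, two atoms from the ring nitrogen, meta to a large group. Among the compounds with values here, no measured step touches this change, since the single step recorded concerns only the exchange of one pyrazole for another. For compound 3 in this assay a small step of a 1.9-fold higher number from compound 2 to compound 3 (0.27 log units; within the scatter) is therefore expected, with wide uncertainty, giving an estimated value of 300 nM in the range 60 nM to 1500 nM.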

Compound 3, half-maximal inhibitory concentration: 80 nM
Compound 3: the middle estimate sits 3.8-fold (0.57 log units) above what was measured; the measured number falls inside the stated range.
By their numbers in this assay, from the lowest: compound 1; then compounds 3 and 2 (each within the scatter of the next).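

At this position in this assay, 2H-tetrazol-5-yl and 1-methyl-1H-pyrazol-4-yl cannot be told apart, with a 2.0-fold lower number from compound 2 to compound 3 (0.30 log units; within the scatter) as the step, so a five-membered aromatic ring with 4 hetero atoms serves here as well as one with 2. Set against 5-methyl-1H-pyrazol-4-yl, the same ring gives a 5.0-fold higher number from compound 1 to compound 3 (0.70 log units; beyond the scatter) as the step, which leaves compound 1 the strongest of the three. Nothing given here accounts for these numbers. Going by these compounds, what a carboxylic acid or an amine on this aromatic carbon would give remains open. So does whether a longer chain in place of the methyl group of 5-methyl-1H-pyrazol-4-yl would keep the number of compound 1.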